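A few compounds are considered here, and "the series" means these few. Any claim that something is new, unique, unknown or untested is made for them only; others in the source may bear on it.

Working notes on the series. In a functional assay on BGC-823 cells (Homo sapiens) for antiproliferative activity, read by MTT assay, tested at 5 uM (on this read-out higher numbers stand for a stronger effect at the one concentration tested and lower numbers for a weaker effect), compound 1 `COc1ccc(C2OC(c3cc(OC)c(OC)c(OC)c3)=NN2C(C)=O)c(OC)c1` gives -3.1%, the lowest of the three numbers measured. Compound 3 `COc1cc(C(=O)N/N=C/c2cccc(C(F)(F)F)c2)cc(OC)c1OC` gives 33.8%, a number beyond the scatter above compound 1, and compound 2 `COc1cc(C(=O)N/N=C/c2ccccc2F)cc(OC)c1OC` gives 76.5%, the furthest above compound 1. For the measured compounds named here, compounds 2 and 3 share neither the core of compound 1 nor a single-point relation to it, so no step is counted between them. Compound 4 `COc1cc(C2=NN(C(C)=O)C(c3ccccc3F)O2)cc(OC)c1OC` keeps the core of compound 1; the difference is 2-fluorophenyl in place of 2,4-dimethoxyphenyl on a saturated ring carbon. Going by the values given here, with no measured step for a change of this kind on this core, the expectation for this assay is a rise of moderate size, with wide uncertainty. The estimate for compound 4 is 25%, within -5% to 60%. That estimate means a step of a number 28.1 percentage points higher from compound 1 to compound 4 (beyond the scatter), expected to exceed the scatter.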

Compound 4, a percentage reported as inhibition, at one concentration (the size of the read-out at that concentration, not a potency): 32.8%
Estimate against measurement, compound 4: 7.8 percentage points below; the measured number falls inside the stated range.
By their numbers in this assay, from the lowest: compound 1; then compounds 4 and 3 (each within the scatter of the next); then compound 2.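

Placing 2-fluorophenyl in place of 2,4-dimethoxyphenyl on the saturated ring carbon gives a number 35.9 percentage points higher from compound 1 to compound 4 (beyond the scatter) in this assay, so the substituent at this position changes the read-out on the core of compound 1. This single change is enough to lift the inactive compound 1 to a clear effect at the one concentration tested. Nothing at hand explains the size of this step.

As far as these compounds go, it remains open whether the rise follows from the added fluorine or from the lost methoxy groups. A plain phenyl or a 4-fluorophenyl at this position would help separate the two.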